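This account rests on a few compounds, and the source may have more. Where it says the series, first, only, none or still open, it means among the compounds named here.

Measured compounds:
compound 1 `COc1ccc2oc(SCCC(=O)N3CCCC3)nc2c1`: 198 mL/min/g
compound 2 `O=C(CCSc1nc(-c2ccccc2)co1)N1CCCC1`: "not determined" (no result reported)
compound 3 `O=C(CCSc1nc2cc(F)c(F)cc2o1)N1CCCC1`: 45.9 mL/min/g

In an ADME assay on microsomes from liver (Mus musculus) for metabolic stability, read by LC-MS, using NADPH, with a stated time of 45 min, tested at 0.5 uM (on this read-out lower numbers stand for slow clearance and higher numbers for fast clearance), compound 1 gives 198 mL/min/g, the highest of the two numbers available. Compound 3 gives 45.9 mL/min/g in this assay, a lower number that lies beyond the usual scatter. Compound 2 has no result in this assay. The next compound, compound 4 `O=C(CCSc1nc2ccccc2o1)N1CCCC1`, differs from compound 1 in one place: hydrogen in place of methoxy on an aromatic carbon. Within the data shown here, no measured pair shows this same change, so the direction is not fixed by the data. Compound 4 is expected to give a somewhat lower number than compound 1, a step of about a 1.7-fold lower number from compound 1 to compound 4 (0.22 log units; within the scatter), close to the edge of the scatter. Compound 4 is therefore estimated at 120 mL/min/g, between 50 mL/min/g and 260 mL/min/g.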

Compound 4, intrinsic clearance in a liver preparation (reported as CLH), per the amount of preparation that the assay uses: 161 mL/min/g
Estimate against measurement, compound 4: 1.3-fold (0.13 log units) below, within the range that was stated.
By their numbers in this assay, from the lowest: compound 3; then compounds 4 and 1 (each within the scatter of the next).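

In this assay, the first pair differing in one place gives a 1.2-fold lower number from compound 1 to compound 4 (0.09 log units; within the scatter). At this aromatic carbon of the six-membered aromatic ring, methoxy and hydrogen therefore cannot be told apart on this read-out, so the methoxy group of compound 1 is not shown to matter for the clearance number. No measurement at hand offers an explanation for this result. The compounds shown leave open whether an amine or a carboxylic acid on this same aromatic carbon would give a number beyond the scatter from compound 4.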